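This account rests on a few compounds, and the source may have more. Where it says the series, first, only, none or still open, it means among the compounds named here.

Compound 1 `CNc1nc(NC2CCCC2)nc(NC2(C#N)CCCCC2)n1` in an in vitro assay on Sf21 cells for inhibition of high affinity 3',5'-cyclic-AMP phosphodiesterase 7A (Homo sapiens) (on this read-out higher numbers stand for weaker inhibition and lower numbers for stronger inhibition), gives > 5000 nM, which is a limit of the assay and not a number.
Compound 2 `CNc1nc(NC2(C#N)CCCCC2)nc(-n2cncn2)n1` in this assay gives > 5000 nM, again a limit rather than a number.
Compound 3 `CNc1nc(NC2(C#N)CCCCC2)nc(N(C)C)n1` in this assay gives > 5000 nM, also a limit and not a number.

Compound 2 thus stands at the edge of what this assay can report, and the other two values shown sit in the same place: the limit of > 5000 nM in this assay, at which 3 of the 3 values shown sit. For the measured compounds named here, as a result none of the measured steps has a readable size. The step that the two limits leave unreadable from compound 1 to compound 2 exchanges one group at the same carbon for another, a step that the two limits leave unreadable from compound 1 to compound 3 does the same with a third group, and a step that the two limits leave unreadable from compound 2 to compound 3 links the latter two; in each case the two limits hide how large the step was and in which direction it ran.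

Compound 4 `CNc1nc(NC2(C#N)CCCCC2)nc(N2CCCC2)n1` has not been measured. It differs from compound 2 in one place: pyrrolidin-1-yl in place of 1H-1,2,4-triazol-1-yl on an aromatic carbon. The three measured steps bear on this change, as each of them also swaps the group at this carbon, but all three are unreadable, so no size or direction can be taken from them. Going by the values given here, every exchange at this position so far left the value at the limit, and the expectation is the same here. Compound 4 is expected to give about 8000 nM in this assay, within a range from 2500 nM to 30000 nM. The step this estimate means is expected to be a step that the limit leaves unreadable from compound 2 to compound 4, which is no change that can be read against the limit.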

Compound 4, half-maximal inhibitory concentration: > 5000 nM
Compound 4 gave a limit, no number (the forecaster's own chance of this, stated with the estimate: 80%); the middle value lies beyond the limit too.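

No step from compound 1, compound 2 or compound 3 to compound 4 can be read, because compound 4 also gives a limit and not a number: the limit of > 5000 nM in this assay, at which 4 of the 4 values shown sit.

The compounds shown leave open how strongly each one inhibits in this assay, and whether exchanging the group at this aromatic carbon changes that inhibition at all.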